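The compounds below may be only part of what the source reports. "The series", "measured", "known", "first", "only" and "open" are said of these compounds alone.

Of the compounds shown here, two have been measured so far. Compound 1 `Cc1cc(-c2ccccc2)n(/C(N)=N/S(=O)(=O)c2cc(C)c(Cl)cc2SCc2cccc3ccccc23)n1` was tested in a functional assay on MCF7 cells (Homo sapiens) for cytotoxicity, read by MTT assay, with a stated time of 72 h (a higher number here means a weaker inhibitor, a lower number a stronger inhibitor), and gives 170000 nM, the highest of the two numbers recorded. Compound 2 `Cc1cc(S(=O)(=O)/N=C(\N)n2nccc2-c2ccccc2)c(SCc2ccc(C(F)(F)F)cc2)cc1Cl` gives 25000 nM in this assay, a lower number than compound 1, and that gap lies beyond the ordinary scatter of repeated runs. Compound 3 `Cc1cc(-c2ccccc2)n(/C(N)=N/S(=O)(=O)c2cc(C)c(Cl)cc2SCc2ccccc2)n1` has not yet been measured; it arises from compound 1 by a single alteration: phenyl in place of naphthalen-1-yl on a saturated chain carbon bound to a sulfur. Among the compounds with values here, no pair of measured compounds shows the effect of this particular change, so there is no measured step to lean on. Compound 1 already sits at a weak level, and the remaining group is a smaller ring of the same kind, so compound 3 is expected to land near compound 1, with the step of a 1.2-fold higher number from compound 1 to compound 3 (0.07 log units; within the scatter) estimated to be within the scatter. The value for compound 3 is estimated at 200000 nM, with a range from 60000 nM to 600000 nM.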

Compound 3, half-maximal inhibitory concentration: 15000 nM
For compound 3 the middle estimate is 13-fold (1.12 log units) above the measured one, and the stated range ends above it.
By their numbers in this assay, from the lowest: compounds 3 and 2 (each within the scatter of the next); then compound 1.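

Within the data shown here, until now no pair of measured compounds showed what the group on this saturated chain carbon bound to a sulfur does. In this assay replacing naphthalen-1-yl with phenyl gives an 11-fold lower number from compound 1 to compound 3 (1.05 log units; beyond the scatter) and so moves the result well beyond ordinary assay scatter. The change removes one of the two aromatic carbon rings and adds no hydrogen-bond donor, acceptor or charge, so this single comparison shows that the size of the carbon ring system at this place can matter, with the smaller ring giving the stronger result here.

Going by these compounds, it remains open whether the trend would continue with a smaller group such as methyl, or how a nitrogen-containing ring such as pyridin-3-yl would behave at the same place. No measurement available here explains the size of this step.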